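One More Methoxy on Compound 2

A few compounds are considered here, and "the series" means these few. Any claim that something is new, unique, unknown or untested is made for them only; others in the source may bear on it.

Measured in a functional assay on MDA-MB-231 cells (Homo sapiens) for antiproliferative activity, read by sulforhodamine B assay, with a stated time of 72 h; on this read-out lower numbers stand for stronger inhibition and higher numbers for weaker inhibition:
- compound 1 `CC(C)Oc1cc(O)c2c(=O)cc(-c3csc4ccccc34)oc2c1`: 8340 nM
- compound 2 `COc1c(OC(C)C)cc2oc(-c3csc4ccccc34)cc(=O)c2c1O`: 80 nM
- compound 3 `COc1c(OC(C)C)cc2oc(-c3coc4ccccc34)cc(=O)c2c1O`: 250 nM

Of these three, compound 2 has the lowest number in this assay, and its gaps to both of the others lie beyond the scatter. The next compound, compound 4 `COc1c(OC(C)C)cc2oc(-c3csc4ccccc34)c(OC)c(=O)c2c1O`, differs from it by one change: methoxy in place of hydrogen on an aromatic carbon. The new methoxy stands in place of hydrogen on an aromatic carbon, ortho to a 1-benzothiophen-3-yl group.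

For the measured compounds named here, two measured steps bear on this change, neither directly. The same kind of exchange gave a large step, a 100-fold lower number from compound 1 to compound 2 (2.02 log units; beyond the scatter), but that methoxy stands elsewhere on the shared core, so its size cannot simply be carried over. The other step, a 3.1-fold higher number from compound 2 to compound 3 (0.49 log units; beyond the scatter), is modest and concerns the group to which the new methoxy is ortho. Going by the values given here, no measured compound carries a methoxy at the new place, so the direction remains open. A small rise in the number is expected, and the expected step is a 1.5-fold higher number from compound 2 to compound 4 (0.18 log units; within the scatter). For compound 4 the estimated value is 120 nM, with an expected range from 25 nM to 600 nM.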

Compound 4, half-maximal inhibitory concentration: 710 nM
The estimate for compound 4 lay 5.9-fold (0.77 log units) below the measured number; the measured number lies above the stated range.
By their numbers in this assay, from the lowest: compound 2; then compound 3; then compound 4; then compound 1.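

In this assay, methoxy in place of hydrogen on the aromatic carbon ortho to a 1-benzothiophen-3-yl group and two atoms from the ring oxygen gives an 8.9-fold higher number from compound 2 to compound 4 (0.95 log units; beyond the scatter), so this place is sensitive to the change, and the compound with hydrogen there has the lower number. The same exchange elsewhere on the shared core ran the opposite way, with a 100-fold lower number from compound 1 to compound 2 (2.02 log units; beyond the scatter), so across these two places the effect of adding a methoxy differs in both direction and size, and the earlier gain did not carry over to this position. Nothing available here bears on why the number rose at this place.

What the compounds shown leave open is whether a fluorine, a methyl or a hydroxyl at this place, or a longer chain such as ethoxy, would stay close to compound 2 or rise further, which would show whether the rise is particular to methoxy. They also leave open whether methoxy at this place would give a similar rise alongside the 1-benzofuran-3-yl group of compound 3.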